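Removing the nitro group from compound 2

A few compounds are considered here, and "the series" means these few. Any claim that something is new, unique, unknown or untested is made for them only; others in the source may bear on it.

In a functional assay on SW480 cells (Homo sapiens) for antiproliferative activity, read by CCK-8 assay and cell counting, with a stated time of 72 h (a higher number here means a weaker inhibitor, a lower number a stronger inhibitor), compound 1 (`O=C(Nc1ccccc1OC(=O)c1ccc(CO[N+](=O)[O-])cc1)c1ccc(CO[N+](=O)[O-])cc1`) stands at 3800 nM and compound 2 (`O=C(Nc1ccccc1)c1ccc(CO[N+](=O)[O-])cc1`) at 800 nM as the lower of the two numbers, a gap beyond the scatter. Compound 3 (`O=C(Nc1ccccc1)c1ccc(CO)cc1`) carries hydrogen in place of nitro on an oxygen on a saturated carbon, so that (nitrooxy)methyl becomes hydroxymethyl. Within the data shown here, no measured compound lacks the nitrooxy group, so the size of this change is a judgement. A weakening beyond the scatter is expected, with an estimated 13-fold higher number from compound 2 to compound 3 (1.10 log units; beyond the scatter) in this assay as the working figure. Compound 3 is estimated at 10000 nM as the expected value (2500 nM to 40000 nM).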

Compound 3, half-maximal inhibitory concentration: > 100000 nM
Compound 3: only a limit was reported; the forecaster's own chance of this, stated with the estimate: 30%; middle value at least 10-fold (1.00 log units) away from the limit.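

In this assay the first comparison across the change from (nitrooxy)methyl to hydroxymethyl is a large loss, with an at least 120-fold higher number from compound 2 to compound 3 (2.09 log units; beyond the scatter). Compound 3 gives > 100000 nM, which is a limit and not a number, so the step has no upper end: the limit of > 100000 nM in this assay, at which 1 of the 3 values shown sits. Activity in this series therefore depends strongly on what sits on this oxygen, which compounds 1 and 2, both carrying nitrooxy, could not show.

As far as these compounds go, whether nitrooxy alone holds this activity remains open. An amine or a methoxy group on the same saturated carbon would test this.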